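Swapping the pendant aryl group of compound 2

The source may report more compounds than this note shows. Statements on the series, on what has been measured and on what is new or still open speak of the compounds shown alone.

Compound 1 `COc1ccc(/C=C2\C(=O)N(c3c(Cl)cccc3Cl)c3ccccc32)cc1OC`: < 1 ug/mL
Compound 2 `O=C1/C(=C\c2ccc(F)cc2)c2ccccc2N1c1c(Cl)cccc1Cl`: 8 ug/mL
Compound 3 `Cc1ccc2nc(Cl)c(/C=C3\C(=O)N(c4c(Cl)cccc4Cl)c4ccccc43)cc2c1C`: < 1 ug/mL

Of the compounds shown here, three sharing one core have been tested in a functional assay on HuTu80 cells (Homo sapiens) for cytotoxicity, read by MTT assay, with a stated time of 72 h; a lower number here means that less compound is needed, a higher number that more compound is needed for the effect. For compound 1 the value of < 1 ug/mL is a limit of the assay, not a number. For compound 3 the value of < 1 ug/mL is likewise a limit. Compound 2 is therefore the only one of the three with a measured number, 8 ug/mL, and it stands apart from the limit of < 1 ug/mL in this assay, at which 2 of the 3 values shown sit.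

Compound 4 `O=C1/C(=C\c2ccccc2[N+](=O)[O-])c2ccccc2N1c1c(Cl)cccc1Cl` has not yet been tested in this assay. It differs from compound 2 in one place: 2-nitrophenyl in place of 4-fluorophenyl on a double-bonded chain carbon bound to a double-bonded ring carbon. For the measured compounds named here, no pair of measured compounds shows the effect of this particular change, so the direction can only be estimated. Two of the three measured compounds sit at the limit, which suggests the shared core can reach there, and compound 2 is expected to move toward it, giving a step of a 2.0-fold lower number from compound 2 to compound 4 (0.30 log units; within the scatter). The value for compound 4 in this assay is expected to be about 4 ug/mL, with a likely range from 1 ug/mL to 16 ug/mL.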

Compound 4, concentration for half-maximal effect: 10 ug/mL
Estimate against measurement, compound 4: 2.5-fold (0.40 log units) below; the measured number falls inside the stated range.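

In this assay, 2-nitrophenyl in place of 4-fluorophenyl gives a 1.3-fold higher number from compound 2 to compound 4 (0.10 log units; within the scatter), so the two groups cannot be told apart at this position. For the compounds shown here, this is the first pair in which both compounds carry a number, and it shows that a group with hydrogen-bond acceptors and more heavy atoms can replace one without such acceptors with no readable difference in this cell test. Steps to compound 1 and compound 3 cannot be read, as each of them carries a limit and not a number: the limit of < 1 ug/mL in this assay, at which 2 of the 4 values shown sit.

As far as these compounds go, what an amine or a carboxylic acid on the pendant aromatic ring would give at this place remains open. From the compounds shown here alone, whether compound 2 and compound 4 would also read alike on other cell types remains open too.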